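Compound 1 to compound 4: a chlorophenyl swap

The source may report more compounds than this note shows. Statements on the series, on what has been measured and on what is new or still open speak of the compounds shown alone.

Values so far in an ADME assay on cells (Lymphocyte, Homo sapiens) for cytotoxicity, read by MTT assay; a lower number here means that less compound is tolerated, a higher number that more compound is tolerated
- compound 1 (`Clc1ccc(C(Nc2ccnc3cc(Cl)ccc23)c2ccc(CN3CCCC3)cc2)cc1`): 17.3 uM
- compound 2 (`COc1ccc2nccc(NC(c3ccc(Cl)cc3)c3ccc(CN4CCCC4)cc3)c2c1`): "not determined" (no result reported)
- compound 3 (`FC(F)(F)c1ccc2c(NC(c3ccc(Cl)cc3)c3ccc(CN4CCCC4)cc3)ccnc2c1`): 24.2 uM

Compound 2 has no result, which leaves two numbers for the series. For the measured compounds named here, compound 1 holds one of them, and the other cannot be told apart from it: the single measured step is a 1.4-fold higher number from compound 1 to compound 3 (0.15 log units; within the scatter) with trifluoromethyl in place of chloro on an aromatic carbon.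

Compound 4 (`Clc1cccc(C(Nc2ccnc3cc(Cl)ccc23)c2ccc(CN3CCCC3)cc2)c1`) has not yet been measured. It has the same atoms as compound 1, joined differently (3-chlorophenyl in place of 4-chlorophenyl on a saturated chain carbon bound to an aromatic carbon and a nitrogen on an aromatic ring). In words, 3-chlorophenyl stands in place of 4-chlorophenyl on a saturated chain carbon bound to an aromatic carbon and a nitrogen on an aromatic ring.

Going by the values given here, no measured step involves this group. Among the compounds with values here, the only indirect evidence is a change at a different place on the core of compound 1, which gave a 1.4-fold higher number from compound 1 to compound 3 (0.15 log units; within the scatter) as its whole effect. One step is thin support, and it offers no direction. No step beyond the scatter is therefore expected in this assay for the swap. The estimate amounts to a 1.0-fold higher number from compound 1 to compound 4 (0.02 log units; within the scatter) as the expected outcome. The estimated value for compound 4 is 18 uM with an expected range of 9 uM to 35 uM as the working band.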

Compound 4, half-maximal toxic concentration: 54.1 uM
Beside the measured number, compound 4's estimate is 3.0-fold (0.48 log units) below it; measured number above the stated range.
By their numbers in this assay, from the lowest: compounds 1 and 3 (each within the scatter of the next); then compound 4.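

In this assay, 3-chlorophenyl in place of 4-chlorophenyl on the saturated chain carbon gives a 3.1-fold higher number from compound 1 to compound 4 (0.50 log units; beyond the scatter), so this place in the series can shift the number beyond the scatter, which the earlier step, a 1.4-fold higher number from compound 1 to compound 3 (0.15 log units; within the scatter), did not show at its different place on the core. The leaving and entering groups have the same heavy atoms, the same aromatic ring and the same donor and acceptor counts, so a change in how the chlorine is joined to the phenyl ring is enough here to move the result, with no change of atoms at all. No measurement in hand explains the rise, so the result stands as an observation on a single pair.

The compounds shown leave open whether the same swap would give a comparable step on the trifluoromethyl-bearing compound 3, since one pair cannot show whether the effect carries over to another substituent on the core. They also leave open how a phenyl without chlorine, or a fluorophenyl or methoxyphenyl, would read at this place.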